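The source may hold more compounds than are shown below. What is called first, only, known or untested is meant among the compounds shown, and "the series" means these compounds.

Of the compounds shown here, three sharing one core have been measured in a physicochemical assay for solubility, read by HPLC; on this read-out higher numbers stand for higher solubility and lower numbers for lower solubility. Compound 1 `O=C(c1ccccc1F)N1CCN(c2nc(=O)c3cc(C(F)(F)F)cc([N+](=O)[O-])c3s2)CC1` carries a 2-fluorophenyl group on the carbonyl carbon, and in this assay compound 1 gives 3.1 ug/mL. Compound 2 `O=C(C1CC1)N1CCN(c2nc(=O)c3cc(C(F)(F)F)cc([N+](=O)[O-])c3s2)CC1` carries a cyclopropyl group in that place, and compound 2 gives 52.9 ug/mL. Compound 3 `CC(C)CC(=O)N1CCN(c2nc(=O)c3cc(C(F)(F)F)cc([N+](=O)[O-])c3s2)CC1` carries an isobutyl group there, and compound 3 gives 66.3 ug/mL, the highest of the three numbers. Against the aryl-bearing compound the difference is marked: a 17-fold higher number from compound 1 to compound 2 (1.23 log units; beyond the scatter) and a 21-fold higher number from compound 1 to compound 3 (1.33 log units; beyond the scatter). Between the two compounds with small aliphatic groups on the carbonyl carbon, however, the step is modest, a 1.3-fold higher number from compound 2 to compound 3 (0.10 log units; within the scatter), so the two are indistinguishable within the usual scatter.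

Compound 4 `O=C(C1CCC1)N1CCN(c2nc(=O)c3cc(C(F)(F)F)cc([N+](=O)[O-])c3s2)CC1` is the next member, not yet measured. It differs from compound 3 in one place: cyclobutyl in place of isobutyl on a carbonyl carbon. The step that bears most directly on this change is the one from a cyclopropyl to an isobutyl group, which stayed within the scatter. Swapping one small aliphatic group for another of the same size is therefore expected to move the number little, if at all: a 1.3-fold lower number from compound 3 to compound 4 (0.12 log units; within the scatter). For compound 4 the solubility in this assay is estimated at 50 ug/mL, with a range from 25 ug/mL to 100 ug/mL.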

Compound 4, solubility: 39.3 ug/mL
For compound 4 the middle estimate is 1.3-fold (0.10 log units) above the measured one, within the range that was stated.
By their numbers in this assay, from the lowest: compound 1; then compounds 4, 2 and 3 (each within the scatter of the next).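

In this assay the change from isobutyl to cyclobutyl on the carbonyl carbon gives a 1.7-fold lower number from compound 3 to compound 4 (0.23 log units; within the scatter) and the change from cyclopropyl to cyclobutyl gives a 1.3-fold lower number from compound 2 to compound 4 (0.13 log units; within the scatter) so this position shows no measurable difference between an open chain and either of two small non-aromatic carbon rings. A third small aliphatic group also stays far from the aryl compound, with a 13-fold higher number from compound 1 to compound 4 (1.10 log units; beyond the scatter) and so compounds 2, 3 and 4 form one group of similar numbers, with compound 1 and its 2-fluorophenyl group well apart and no listed compound going against this. No accompanying measurement indicates what lies behind these numbers.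

Going by these compounds, it remains open whether the low number of compound 1 goes with an aromatic ring as such or with its fluorine, a question that a plain phenyl or a pyridine ring on the same carbonyl carbon could address. The compounds shown also leave open how far the number would move with a group that carries an amine, a carboxylic acid or an ether oxygen, or with a longer carbon chain.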